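Lipophilicity step from compound 1 to compound 3

This account rests on a few compounds, and the source may have more. Where it says the series, first, only, none or still open, it means among the compounds named here.

Values in a physicochemical assay for lipophilicity, read by HPLC, measured as octanol-water partition; on this read-out lower numbers stand for lower lipophilicity and higher numbers for higher lipophilicity
- compound 1 `Nc1ccccc1C(=O)N/N=C/c1ccc2no[n+]([O-])c2c1` (2)
- compound 2 `NC(=O)c1c(COc2ccccc2/C=N/NC(=O)c2ccncc2)no[n+]1[O-]` (1.3)

Among the compounds with values here, of these two numbers, the one for compound 1 (2) is the higher, and the gap down to compound 2 lies beyond the scatter. Compound 3 `O=C(N/N=C/c1ccc2no[n+]([O-])c2c1)c1ccc(O)cc1` has not yet been measured. It differs from compound 1 in one place 4-hydroxyphenyl in place of 2-aminophenyl on a carbonyl carbon with 4-hydroxyphenyl in place of 2-aminophenyl on a carbonyl carbon. Within the data shown here, no measured pair shows this change, so the expectation starts from compound 1 (2) and the structural change alone. In this assay a slight downward move is expected, with the estimated step of a number 0.20 log units lower from compound 1 to compound 3 (within the scatter) staying within the scatter. For compound 3 the estimated value is 1.8 (expected range 1.3 to 2.3).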

Compound 3, partition coefficient: 1.2
Estimate against measurement, compound 3: 0.60 log units above; the whole stated range lies above it.
By their numbers in this assay, from the lowest: compounds 3 and 2 (each within the scatter of the next); then compound 1.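

In this assay, within the data shown here, the exchange of 2-aminophenyl for 4-hydroxyphenyl on a carbonyl carbon gives a number 0.80 log units lower from compound 1 to compound 3 (beyond the scatter) with the rest of compound 1 unchanged, the first single-place step. The read-out therefore responds to the aryl group at this position. The two groups have equal counts of heavy atoms, hydrogen-bond donors and hydrogen-bond acceptors and carry no net charge, so these counts do not account for the difference, and no measurement available explains the step.

This one pair changes both the substituent and the number in the group's name, so it cannot separate the loss of the amino group, the arrival of the hydroxyl group and the different ring numbering. From the compounds shown here alone, how a plain phenyl group or a carboxylic acid on the phenyl ring would read at this carbonyl carbon remains open.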